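The source may hold more compounds than are shown below. What is called first, only, known or untested is meant among the compounds shown, and "the series" means these compounds.

Measured in a functional assay on BE(2)-C cells (Homo sapiens) for inhibition, read by MTT assay, with a stated time of 72 h; on this read-out lower numbers stand for stronger inhibition of growth and higher numbers for weaker inhibition of growth:
compound 1 `O=S(=O)(NCCNCc1ccc(-c2ccccc2)cc1)c1cc(C(F)(F)F)cc(C(F)(F)F)c1` — 2700 nM
compound 2 `O=S(=O)(NCCCNCc1ccc(Cl)c(C(F)(F)F)c1)c1cc(C(F)(F)F)cc(C(F)(F)F)c1` — 8600 nM
compound 3 `O=S(=O)(NCCCNCc1ccccc1)c1cc(C(F)(F)F)cc(C(F)(F)F)c1` — 12000 nM

Compound 3 gives the highest of the three numbers in this assay. Its nearest neighbour is compound 2, and a 1.4-fold higher number from compound 2 to compound 3 (0.14 log units; within the scatter) lies within the scatter. Within the data shown here, compound 1, which differs from compound 3 in both the chain and the aryl group, gives a number well below it, beyond the scatter, but no single step connects the two.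

Compound 4 `O=S(=O)(NCCCNCc1ccc(Cl)cc1)c1cc(C(F)(F)F)cc(C(F)(F)F)c1` differs from compound 3 by chloro in place of hydrogen on an aromatic carbon. Among the measured compounds shown here, the only measured step that bears on this change is the one between compound 2 and compound 3, where the aryl ring carried both chloro and trifluoromethyl, and there a 1.4-fold higher number from compound 2 to compound 3 (0.14 log units; within the scatter) stayed within the scatter. Compound 4 carries the chloro alone, so the expected step of a 1.3-fold lower number from compound 3 to compound 4 (0.12 log units; within the scatter) is small, if anything toward a lower number, and not clearly beyond the scatter. In this assay compound 4 is therefore estimated at 9000 nM, with a range of 4000 nM to 25000 nM.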

Compound 4, concentration for 50% growth inhibition: 2900 nM
For compound 4 the middle estimate is 3.1-fold (0.49 log units) above the measured one; measured number outside the range, below it.
By their numbers in this assay, from the lowest: compounds 1 and 4 (each within the scatter of the next); then compounds 2 and 3 (each within the scatter of the next).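

In this assay, chloro alone, para to a large group, is enough for a step beyond the scatter: a 4.1-fold lower number from compound 3 to compound 4 (0.62 log units; beyond the scatter). Removing trifluoromethyl from the 4-chloro-substituted ring also gives a step beyond the scatter: a 3.0-fold lower number from compound 2 to compound 4 (0.47 log units; beyond the scatter). The earlier step within the scatter, a 1.4-fold higher number from compound 2 to compound 3 (0.14 log units; within the scatter), therefore does not show that the aryl substituents are without consequence, since it combines these two opposite steps; no data at hand explain either one.

From the compounds shown here alone, whether fluoro, bromo or methoxy in place of chloro would give a step of similar size remains open. Also open, going by these compounds, is whether chloro would give the same step on the chain of compound 1, or whether a longer chain would change the picture.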